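Bromo to amino on the side chain

The source may hold more compounds than are shown below. What is called first, only, known or untested is meant among the compounds shown, and "the series" means these compounds.

Values measured so far in a functional assay on HCT-8 cells (Homo sapiens) for antiproliferative activity, read by MTT assay, with a stated time of 48 h (a lower number here means a stronger inhibitor, a higher number a weaker inhibitor), for the three compounds:
- compound 1 `COc1ccc(C(=O)c2ccc(OC)c3c2OC(C)(C)C=C3)c(NC(=O)CBr)c1` gives 3250 nM
- compound 2 `COc1ccc(C(=O)c2ccc(OC)c3c2C=CC(C)(C)O3)c(NC(=O)CBr)c1` gives 4360 nM
- compound 3 `COc1ccc(C(=O)c2ccc(OC)c3c2C=CC(C)(C)O3)c(NC(=O)CO)c1` gives 630 nM

Compound 1 at 3250 nM and compound 2 at 4360 nM lie within the scatter of each other, while compound 3 at 630 nM sits clearly lower than both. Compound 4 `COc1ccc(C(=O)c2ccc(OC)c3c2OC(C)(C)C=C3)c(NC(=O)CN)c1` has not yet been measured. It differs from compound 1 by amino in place of bromo on a saturated chain carbon bound to a carbonyl carbon in all, which is amino in place of bromo on a saturated chain carbon bound to a carbonyl carbon. The closest measured evidence is a 6.9-fold lower number from compound 2 to compound 3 (0.84 log units; beyond the scatter) with hydroxy in place of bromo at that same place. For the measured compounds named here, the core of compound 2 differs from that of compound 1, and no amino compound has been measured, so this single step is only a loose guide. A drop of similar size is still expected, and in this assay the expected result is a 4.6-fold lower number from compound 1 to compound 4 (0.67 log units; beyond the scatter) toward a lower number. The estimate for compound 4 is 700 nM with an expected range from 180 nM to 2600 nM across repeat measurements.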

Compound 4, half-maximal inhibitory concentration: 370 nM
Estimate against measurement, compound 4: 1.9-fold (0.28 log units) above; the measured number falls inside the stated range.
By their numbers in this assay, from the lowest: compounds 4 and 3 (each within the scatter of the next); then compounds 1 and 2 (each within the scatter of the next).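

In this assay the change from bromo to amino on a saturated chain carbon bound to a carbonyl carbon gives an 8.8-fold lower number from compound 1 to compound 4 (0.94 log units; beyond the scatter) and so gives the core of compound 1 a step of its own at this place. For the compounds shown here, the only earlier step here was a 6.9-fold lower number from compound 2 to compound 3 (0.84 log units; beyond the scatter) with hydroxy on the core of compound 2, so a lower number on leaving bromo now holds for two replacements on two cores, and these two steps are all that show it. No measurement at hand explains why the number falls when bromo leaves.

From the compounds shown here alone, whether hydroxy on the core of compound 1 or amino on the core of compound 2 would behave alike stays open, so the part the core plays in these steps cannot be read. Also open, going by these compounds, is how a dimethylamino group, a carboxylic acid or a longer chain would fare at this place in this assay.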